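The compounds below may be only part of what the source reports. "The series", "measured", "known", "first", "only" and "open" are said of these compounds alone.

In a functional assay on MCF7 cells (Homo sapiens) for inhibition, read by sulforhodamine B assay (a lower number here means a stronger inhibitor, a higher number a weaker inhibitor), compound 2 (`O=C1C=C(Nc2ccccc2)C(=O)c2c1nc1n2[C@H]2OC[C@@H](O)[C@H]2OC1`) gives > 4000 nM, which is a limit of the assay and not a number. Compound 1 (`CCc1ccc(NC2=CC(=O)c3nc4n(c3C2=O)[C@H]2OC[C@@H](O)[C@H]2OC4)cc1`), which carries an ethyl group, gives 960 nM in this assay. Among the compounds with values here, the only measured step is an at least 4.1-fold higher number from compound 1 to compound 2 (0.61 log units; beyond the scatter), with hydrogen in place of ethyl on an aromatic carbon.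

Compound 3 (`O=C1C=C(N2CCCC2)C(=O)c2c1nc1n2[C@H]2OC[C@@H](O)[C@H]2OC1`) has pyrrolidin-1-yl in place of anilino on a double-bonded ring carbon. Within the data shown here, the measured step lies on the anilino group, which leaves altogether here, so it gives no size for this replacement, and no measured step covers the replacement itself. No step beyond the scatter is therefore expected in this assay, in either direction, and the expected step is a number no higher from compound 2 to compound 3 (the limit leaves the size open). For compound 3 the estimated value is 4000 nM, with an expected range of 1300 nM to 12000 nM.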

Compound 3, half-maximal inhibitory concentration: > 16000 nM
Compound 3: no number, only a limit (the forecaster's own chance of this, stated with the estimate: 50%); middle value at least 4.0-fold (0.60 log units) away from the limit.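

In this assay compound 3 gives > 16000 nM, which is a limit of the assay and not a number. Pyrrolidin-1-yl on the double-bonded ring carbon, in place of (4-ethylphenyl)amino, gives an at least 16-fold higher number from compound 1 to compound 3 (1.22 log units; beyond the scatter), so this position has now been varied beyond the anilino series, and the one non-aromatic ring shown does not match compound 1. The step between compound 2 and compound 3 cannot be read because both values are limits, the higher one being: the limit of > 16000 nM in this assay, at which 1 of the 3 values shown sits.

Still open, as far as these compounds go, is whether the aromatic ring or the hydrogen-bond donor of the anilino group counts for more at this carbon, since pyrrolidin-1-yl lacks both. A benzylamino group or piperidin-1-yl at this carbon, or a propyl chain in place of the ethyl group, would bear on that question.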